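The compounds below may be only part of what the source reports. "The series", "measured", "known", "first", "only" and "open" are said of these compounds alone.

Measured so far:
- compound 1 `CN1CCN(c2ccc(C3=NN(S(C)(=O)=O)C(c4ccc(N(C)C)cc4)C3)cc2)CC1`: in a functional assay on HCC1806 cells (Homo sapiens) for inhibition, read by sulforhodamine B assay, tested at 10 uM (on this read-out lower numbers stand for less inhibition and higher numbers for more inhibition at the one concentration tested (going by the name of the read-out)), compound 1 gives -18.5%
- compound 2 `Cc1ccc(S(=O)(=O)N2N=C(c3ccc(N4CCN(C)CC4)cc3)CC2c2ccc(N(C)C)cc2)cc1`: in this assay compound 2 gives 32.2%
- compound 3 `CN(C)c1ccc(C2CC(c3ccc(-n4cncn4)cc3)=NN2S(C)(=O)=O)cc1`: in this assay compound 3 gives 10.8%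

Compound 4 `Cc1ccc(S(=O)(=O)N2N=C(c3ccc(-n4cncn4)cc3)CC2c2ccc(N(C)C)cc2)cc1` is the one not yet measured. It differs from compound 3 by 4-methylphenyl in place of methyl on a sulfonyl sulfur. The same change is made from compound 1 to compound 2, where it gave a number 50.7 percentage points higher from compound 1 to compound 2 (beyond the scatter). The two cores differ by 1H-1,2,4-triazol-1-yl in place of 4-methylpiperazin-1-yl on an aromatic carbon, a change that on its own gave a number 29.3 percentage points higher from compound 1 to compound 3 (beyond the scatter). The place of the change is the same word for word in both pairs, so the change from compound 3 to compound 4 is the same change.

Within the data shown here, for compound 4 a step of about a number 44.2 percentage points higher from compound 3 to compound 4 (beyond the scatter) is expected, resting on the single earlier instance, because a number 50.7 percentage points higher from compound 1 to compound 2 (beyond the scatter) is the only measurement of this change and the series holds no second pair to check whether it transfers onto the core of compound 3. Some shortfall is allowed for, since the read-out can only climb so far. Compound 4 is estimated at 55%, expected between 30% and 80%.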

Compound 4, a percentage reported as inhibition, at one concentration (the size of the read-out at that concentration, not a potency): 27.7%
Compound 4: the middle estimate sits 27.3 percentage points above what was measured, outside the stated range (below it).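

In this assay the change to 4-methylphenyl on the sulfonyl sulfur again gives a rise, a number 16.9 percentage points higher from compound 3 to compound 4 (beyond the scatter), but its size does not carry over from one core to the other: the same change on two cores in this assay, a number 50.7 percentage points higher (beyond the scatter) from compound 1 to compound 2 and a number 16.9 percentage points higher (beyond the scatter) from compound 3 to compound 4, 33.8 percentage points apart, beyond the scatter of two such steps

The swap to 1H-1,2,4-triazol-1-yl, with 4-methylphenyl on the sulfonyl sulfur, gives a number 4.5 percentage points lower from compound 2 to compound 4 (within the scatter), so this step also depends on the core that carries it: the same change on two cores in this assay, a number 29.3 percentage points higher (beyond the scatter) from compound 1 to compound 3 and a number 4.5 percentage points lower (within the scatter) from compound 2 to compound 4, 33.8 percentage points apart, beyond the scatter of two such steps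

These two pairs show that the two changes do not simply add up, but they do not show why, nor what either step would be on any further core.

Still open, on these data alone, is how a longer chain or an unsubstituted phenyl on the sulfonyl sulfur would compare with methyl and 4-methylphenyl. Also open, as far as these compounds go, is how morpholine or a carboxylic acid would behave in place of 4-methylpiperazin-1-yl or 1H-1,2,4-triazol-1-yl.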